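The source may hold more compounds than are shown below. What is called first, only, known or untested is meant among the compounds shown, and "the series" means these compounds.

Working notes on the series: in a functional assay on HCT-116 cells (Homo sapiens) for antiproliferative activity, read by MTT assay, with a stated time of 24 h (a higher number here means a weaker inhibitor, a lower number a stronger inhibitor), compound 1 (`COc1cc(OC)c(-c2coc3cc(OCC=C(C)C)ccc3c2=O)cc1OC`) gives 680 nM as its read-out. Compound 2 (`COc1cccc(C(=O)Oc2ccc3c(=O)c(-c4cc(OC)c(OC)cc4OC)coc3c2)c1`) gives > 10000 nM as a limit of the assay and not a number. Compound 3 (`COc1cc(OC)c(-c2coc3cc(OCc4ccccc4C#N)ccc3c2=O)cc1OC`) gives > 10000 nM as a limit too, so it stands without a number of its own (the limit of > 10000 nM in this assay, at which 2 of the 3 values shown sit).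

Compound 4 (`COc1cc(OC)c(-c2coc3cc(OCc4cccc(Cl)c4)ccc3c2=O)cc1OC`) carries 3-chlorophenyl in place of 2-cyanophenyl on a saturated chain carbon bound to an oxygen on an aromatic ring.

The nearest measured step is an at least 14-fold higher number from compound 1 to compound 3 (1.16 log units; beyond the scatter) and it is large. The step of an at least 14-fold higher number from compound 1 to compound 2 (1.16 log units; beyond the scatter) is equally large, while a step that the two limits leave unreadable from compound 2 to compound 3 gives no readable size. No readable step exchanges one substituted phenyl for another at this place, so in this assay only a modest move to a lower number, or none that can be read, is expected. The expected step is an at least 1.4-fold lower number from compound 3 to compound 4 (0.15 log units; that floor lies within the scatter) as a rough estimate. For compound 4 the estimated value is 7000 nM within an expected range from 2000 nM to 10000 nM and a read-out at the limit is quite possible.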

Compound 4, half-maximal inhibitory concentration: 1330 nM
For compound 4 the middle estimate is 5.3-fold (0.72 log units) above the measured one; the measured number lies below the stated range.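

The change at this place shows that the group on the saturated chain carbon bound to the oxygen decides the read-out in this assay: replacing 2-cyanophenyl with 3-chlorophenyl gives an at least 7.5-fold lower number from compound 3 to compound 4 (0.87 log units; beyond the scatter). A substituted phenyl at this place is therefore not excluded from a measurable read-out, and the comparison with the 3-methylbut-2-en-1-yl ether gives a 2.0-fold higher number from compound 1 to compound 4 (0.29 log units; within the scatter). The 3-chlorobenzyl group also stands apart from (3-methoxyphenyl)carbonyl on the same oxygen, with an at least 7.5-fold lower number from compound 2 to compound 4 (0.87 log units; beyond the scatter).

As far as these compounds go, whether the shift belongs to the chlorine, to its ring position or to the loss of the nitrile stays open, and an unsubstituted benzyl or a longer alkyl chain would bear on this. Compound 2 and compound 3 each give a limit of the assay, so the step between them cannot be read: the limit of > 10000 nM in this assay, at which 2 of the 4 values shown sit.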